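The compounds below may be only part of what the source reports. "The series", "measured", "known", "first", "only" and "open" are said of these compounds alone.

Of the compounds shown here, two have been tested in a functional assay on MCF7 cells (Homo sapiens) for antiproliferative activity, read by sulforhodamine B assay, with a stated time of 72 h; on this read-out higher numbers stand for weaker inhibition and lower numbers for stronger inhibition. Compound 1, `N#Cc1ccccc1COc1ccc(-c2cc(CN3CCN(Cc4ccc(C(F)(F)F)cc4)CC3)no2)cc1`, gives 4000 nM in this assay. Compound 2, `N#Cc1cccc(COc2ccc(-c3cc(CN4CCN(c5ccc(C(F)(F)F)cc5)CC4)no3)cc2)c1`, gives 2000 nM in this assay. Among the measured compounds shown here, of these two numbers the one for compound 2 is the lower, but the gap to compound 1 lies within the usual scatter of repeated measurements, so the two compounds cannot be told apart on potency from these data.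

Compound 3, `N#Cc1cccc(COc2ccc(-c3cc(CN4CCN(CC5CC5)CC4)no3)cc2)c1`, has not yet been measured in this assay. It differs from compound 2 in one place only: cyclopropylmethyl in place of 4-(trifluoromethyl)phenyl on an amine nitrogen in a ring. No pair of measured compounds differs in the same way, so there is no measured step to lean on for this change; the expectation below rests only on the structures and the two numbers shown. The change is expected to produce a 2.0-fold higher number from compound 2 to compound 3 (0.30 log units; within the scatter), a step toward a higher number in this assay, though one that may not be large. On that basis compound 3 is estimated to give about 4000 nM in this assay, within a range from 1500 nM to 12000 nM.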

Compound 3, half-maximal inhibitory concentration: 3500 nM
The estimate for compound 3 lay 1.1-fold (0.06 log units) above the measured number; the measured number falls inside the stated range.
By their numbers in this assay, from the lowest: compounds 2, 3 and 1 (each within the scatter of the next).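

Among the compounds shown here, putting cyclopropylmethyl in place of 4-(trifluoromethyl)phenyl on the amine nitrogen in the ring gives a 1.8-fold higher number from compound 2 to compound 3 (0.24 log units; within the scatter) in this assay, the first comparison in which only one place changes. The entering group has 4 heavy atoms, fewer than the group that leaves, and it replaces a six-membered aromatic ring and three fluorines with a three-membered non-aromatic ring of carbon only, yet this pair cannot be told apart on potency. At this position, then, and on this shared core, two quite different groups give readings that this assay cannot separate, and nothing at hand bears on why that is so.

On these data alone, what remains open is whether this insensitivity extends to other groups on the same nitrogen, such as a bare hydrogen, a methyl, a longer alkyl chain or a chain ending in a carboxylic acid. As far as these compounds go, it is also open whether any group at this position can move the reading beyond the scatter, or whether changes elsewhere on the core matter more.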